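Series notes: fluoro removal on the aryl tail, cytotoxicity

The source may report more compounds than this note shows. Statements on the series, on what has been measured and on what is new or still open speak of the compounds shown alone.

Three members of the series have been run in an ADME assay on MT2 cells (Homo sapiens) for cytotoxicity, read by XTT assay, with a stated time of 4 days (on this read-out higher numbers stand for lower toxicity in this test and lower numbers for higher toxicity in this test), so far, all with one shared core and different substituents. Compound 1 `Cc1ccc(-c2c3c(nc(C)c2C(OC(C)(C)C)C(=O)O)CCN(Cc2ccccc2-c2ccccc2)C3)cc1` gives > 40000 nM, which is a limit of this assay and not a number. Compound 3 `CC(=O)N1CCc2nc(C)c(C(OC(C)(C)C)C(=O)O)c(-c3ccc(C)cc3)c2C1` likewise reaches only the limit at > 40000 nM. Going by the values given here, compound 2 `Cc1ccc(CCCN2CCc3nc(C)c([C@H](OC(C)(C)C)C(=O)O)c(-c4cc(F)c5c(c4C)CCCO5)c3C2)cc1F`, the starting point here, also returns a limit at > 40000 nM in this assay, so for compound 2 nothing more than this limit is known, and no compound among the three can be set apart from any other.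

Compound 4 `Cc1ccc(CCCN2CCc3nc(C)c([C@H](OC(C)(C)C)C(=O)O)c(-c4cc(F)c5c(c4C)CCCO5)c3C2)cc1` is the next to be measured. Against compound 2 it carries the change (hydrogen in place of fluoro on an aromatic carbon).

Among the compounds with values here, no measured step between two compounds is available. The expectation for the step of a number no higher from compound 2 to compound 4 (the limit leaves the size open) is none beyond the scatter in this assay. Compound 4 is thus expected to come out at 40000 nM, in a range from 20000 nM to 80000 nM, because every measurement so far in this assay sits at the limit of > 40000 nM in this assay, at which 3 of the 3 values shown sit.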

Compound 4, half-maximal cytotoxic concentration: > 40000 nM
Compound 4 ended at the assay's limit; the forecaster's own chance of this, stated with the estimate: 90%; the middle value lies on the limit itself.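

In this assay compound 2 and compound 4 both return only a limit, and the step between them cannot be read. The compounds shown leave open whether hydrogen in place of fluoro on an aromatic carbon changes this read-out at all, since none gives an actual number.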